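Iodo versus phenyl on two related nucleoside cores

The compounds below may be only part of what the source reports. "The series", "measured", "known", "first", "only" and "open" are said of these compounds alone.

Measured in a functional assay on K562 cells (Homo sapiens), read by MTT assay, with a stated time of 72 h; on this read-out higher numbers stand for weaker inhibition and lower numbers for stronger inhibition:
- compound 1 `Cc1nc(N)c2c(-c3ccccc3)cn([C@@H]3O[C@H](CO)[C@@H](O)[C@H]3O)c2n1`: > 20000 nM, a limit of the assay, not a number
- compound 2 `Cc1nc(N)c2c(I)cn([C@@H]3O[C@H](CO)[C@@H](O)[C@H]3O)c2n1`: 1110 nM
- compound 3 `CNc1ncnc2c1c(I)cn2[C@@H]1O[C@H](CO)[C@@H](O)[C@H]1O`: > 20000 nM, a limit of the assay, not a number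

Compound 2 and compound 3 share the same atoms joined differently; the difference between the two cores is not broken down here. On the core of compound 2, the change phenyl in place of iodo on an aromatic carbon gives an at least 18-fold higher number from compound 2 to compound 1 (1.25 log units; beyond the scatter), with compound 1 sitting at the limit of > 20000 nM in this assay, at which 2 of the 3 values shown sit.

Compound 4 `CNc1ncnc2c1c(-c1ccccc1)cn2[C@@H]1O[C@H](CO)[C@@H](O)[C@H]1O` is not yet measured. It differs from compound 3 by phenyl in place of iodo on an aromatic carbon, the same change as from compound 2 to compound 1. Because compound 3 already sits at the limit of > 20000 nM in this assay, at which 2 of the 3 values shown sit, compound 4 is expected to remain at that limit, with an estimated step that the limit leaves unreadable from compound 3 to compound 4. The estimate for compound 4 is 40000 nM, between 15000 nM and 150000 nM.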

Compound 4, half-maximal inhibitory concentration: > 20000 nM
Compound 4: no number, only a limit (the forecaster's own chance of this, stated with the estimate: 90%); the middle value is on the limit's open side.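

Compound 3 and compound 4 both give only a limit, so no step can be read between them: the limit of > 20000 nM in this assay, at which 3 of the 4 values shown sit.

Still open, on these data alone, is what phenyl in place of iodo does on the core of compound 3.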